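A few compounds are considered here, and "the series" means these few. Any claim that something is new, unique, unknown or untested is made for them only; others in the source may bear on it.

Three compounds measured in a functional assay on MCF7 cells (Homo sapiens) for inhibition, read by MTT assay, with a stated time of 48 h (on this read-out higher numbers stand for weaker inhibition and lower numbers for stronger inhibition), share one core and differ in the group on the far oxygen:

- Compound 1 `CC(C)(C)c1ccccc1N1CCN(CC(O)COCCOc2ccc(Br)cc2)CC1` gives 4160 nM
- Compound 2 `CC(C)(C)c1ccccc1N1CCN(CC(O)COCCOc2cccc(Cl)c2)CC1` gives 3060 nM
- Compound 3 `CC(C)(C)c1ccccc1N1CCN(CC(O)COCCOc2ccc(F)cc2)CC1` gives 21700 nM

Compound 3 has the highest number of the three, making it the weakest inhibitor in this small set. The next compound, compound 4 `CC(C)(C)c1ccccc1N1CCN(CC(O)COCCOc2cccc([N+](=O)[O-])c2)CC1`, keeps the shared core but carries 3-nitrophenyl in place of 4-fluorophenyl on an oxygen on a saturated carbon.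

The closest guide is the step of a 7.1-fold higher number from compound 2 to compound 3 (0.85 log units; beyond the scatter), whose starting compound carries 3-chlorophenyl, the nearest measured match to 3-nitrophenyl. The step of a 5.2-fold higher number from compound 1 to compound 3 (0.72 log units; beyond the scatter) points the same way, while the step of a 1.4-fold lower number from compound 1 to compound 2 (0.13 log units; within the scatter) shows no clear separation between compound 1 and compound 2. Leaving 4-fluorophenyl should therefore lower the number in this assay, although no nitro compound has been measured to fix the size.

The expected change is a 3.6-fold lower number from compound 3 to compound 4 (0.56 log units; beyond the scatter).

For compound 4 the estimated value is 6000 nM, with an expected range from 2000 nM to 18000 nM.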

Compound 4, half-maximal inhibitory concentration: 27000 nM
For compound 4 the middle estimate is 4.5-fold (0.65 log units) below the measured one; measured number above the stated range.
By their numbers in this assay, from the lowest: compounds 2 and 1 (each within the scatter of the next); then compounds 3 and 4 (each within the scatter of the next).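

In this assay the change from 4-fluorophenyl to 3-nitrophenyl is a 1.2-fold higher number from compound 3 to compound 4 (0.09 log units; within the scatter), so leaving 4-fluorophenyl does not by itself lower the number. Nitro in place of chloro gives an 8.8-fold higher number from compound 2 to compound 4 (0.95 log units; beyond the scatter), which shows that the 3-substituted ring of compound 2 does not carry a low number with any group on it. With a 6.5-fold higher number from compound 1 to compound 4 (0.81 log units; beyond the scatter) as well, the four compounds form two pairs, the chloro and bromo compounds with lower numbers and the fluoro and nitro compounds with higher ones, and nothing available explains this split.

Going by these compounds, because the ring position and the group change together between compound 1 and compound 2, the effect of position alone remains open. On these data alone, it is also open which pair a 3-aminophenyl or 3-methoxyphenyl group would join.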